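The compounds below may be only part of what the source reports. "The series", "measured", "known", "first", "only" and "open" are said of these compounds alone.

For the measured compounds named here, in an ADME assay on HEK293 cells (Homo sapiens) for cytotoxicity, read by MTT assay, with a stated time of 48 h (on this read-out higher numbers stand for weaker inhibition and lower numbers for stronger inhibition), compound 1 `O=C1/C(=C\c2ccc(O)cc2)S/C(=N/c2ccccc2)N1Cc1ccncc1` gives 142000 nM, and compound 2 `COc1ccc(/C=C2/S/C(=N/c3ccccc3)N(Cc3ccncc3)C2=O)cc1` gives 47900 nM, the lower of the two numbers measured so far. Compound 3 `O=C1/C(=C\c2ccc(Cl)cc2)S/C(=N/c2ccccc2)N1Cc1ccncc1` departs from compound 2 in one place, with chloro in place of methoxy on an aromatic carbon, para to a large group: chloro in place of methoxy on an aromatic carbon. Going by the values given here, only one measured step bears on this change, and it does so indirectly. That step is a 3.0-fold lower number from compound 1 to compound 2 (0.47 log units; beyond the scatter), made by methyl in place of hydrogen on an oxygen on an aromatic ring. Among the compounds with values here, it concerns the methoxy that compound 3 gives up, but no measured compound carries chloro, so the data offer no direction for the new group. Within the data shown here, with that single modest step as the only guide, no shift beyond the scatter is expected in this assay, and a shift of similar modest size in either direction would not be surprising. The expected step is a 1.1-fold lower number from compound 2 to compound 3 (0.06 log units; within the scatter). Compound 3 is estimated at 42000 nM, with an expected range of 16000 nM to 110000 nM.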

Compound 3, half-maximal inhibitory concentration: 42300 nM
Beside the measured number, compound 3's estimate is 1.0-fold (0.00 log units) below it; low and high end bracket the measured number.
By their numbers in this assay, from the lowest: compounds 3 and 2 (each within the scatter of the next); then compound 1.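

Replacing methoxy with chloro on the aromatic carbon, para to a large group, gives a 1.1-fold lower number from compound 2 to compound 3 (0.05 log units; within the scatter) in this assay, so at this position the two groups cannot be told apart on this read-out, even though they differ in heavy atoms and in hydrogen-bond acceptors. Chloro in place of hydroxy gives a 3.4-fold lower number from compound 1 to compound 3 (0.53 log units; beyond the scatter) and thus repeats the modest separation from compound 1 that had so far rested on methoxy alone, with both replacements of hydroxy now ending within the scatter of each other and compound 1 standing apart from the pair. None of the information at hand gives a measured reason for this grouping of the three compounds.

Whether an amine, a carboxylic acid or a fluoro group at this same place would stay with compound 2 and compound 3 or fall nearer to compound 1 remains open, since only three groups are shown there. As far as these compounds go, the rest of the core is the same in all three compounds, so the effect of changing the pyridine-bearing side chain or the other aromatic ring on the numbers in this assay also remains unknown.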